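Methoxy to Fluoro on the Sulfanyl-Linked Phenyl Ring

The compounds below may be only part of what the source reports. "The series", "measured", "known", "first", "only" and "open" are said of these compounds alone.

Compound 1 `Nc1cc(N)c2nc(-c3ccccc3)c(Oc3ccc(Cl)c(Cl)c3)nc2c1`: in a functional assay on SN12C cells (Homo sapiens) for inhibition, read by sulforhodamine B assay, with a stated time of 48 h (a lower number here means that less compound is tolerated, a higher number that more compound is tolerated), compound 1 gives < 100000 nM, which is a limit of the assay.
Compound 2 `COc1ccc(Sc2nc3cc(N)cc(N)c3nc2-c2ccccc2)cc1`: in this assay compound 2 gives 87100 nM.

For the measured compounds named here, compound 2 stands as the only compound with a number in this assay; the other value shown is a limit. The step that the limit leaves unreadable from compound 1 to compound 2 cannot be read, because of the limit of < 100000 nM in this assay, at which 1 of the 2 values shown sits. Compound 3 `Nc1cc(N)c2nc(-c3ccccc3)c(Sc3ccc(F)cc3)nc2c1` differs from compound 2 by fluoro in place of methoxy on an aromatic carbon. Going by the values given here, no measured step touches this change, and the single measured step is unreadable, so nothing among the measured compounds points to a shift in either direction beyond the usual scatter. The step of a 1.0-fold higher number from compound 2 to compound 3 (0.01 log units; within the scatter) is therefore expected to be small. For compound 3 the estimate is 90000 nM, with a range from 30000 nM to 200000 nM, and a real chance that the assay reports only a limit.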

Compound 3, concentration lethal to 50% of the cells: < 100000 nM
Compound 3 ended at the assay's limit (the forecaster's own chance of this, stated with the estimate: 40%); the middle value is on the limit's open side.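

For the compounds shown here, no step to compound 3 from compound 1 or compound 2 can be read, because each of them meets the same boundary: the limit of < 100000 nM in this assay, at which 2 of the 3 values shown sit. What the compounds shown leave open is whether fluoro in place of methoxy changes the value in this assay at all, and in which direction.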